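Trifluoromethyl Addition Carried Over to a Second Core

This account rests on a few compounds, and the source may have more. Where it says the series, first, only, none or still open, it means among the compounds named here.

Compound 1 `CC(O)(CSc1cccc(C(F)(F)F)c1)C(=O)Nc1cccc(S(F)(F)(F)(F)F)c1` and compound 2 `CC(O)(CSc1cc(C(F)(F)F)cc(C(F)(F)F)c1)C(=O)Nc1cccc(S(F)(F)(F)(F)F)c1` share one core, while compound 3 `CC(O)(COc1ccc(C#N)cc1)C(=O)Nc1ccc(S(F)(F)(F)(F)F)cc1` rests on another; the difference between the two cores is not broken down here. In a functional assay on LNCaP cells (Homo sapiens) for antiproliferative activity, read by propidium iodide staining, with a stated time of 96 h (a lower number here means a stronger inhibitor, a higher number a weaker inhibitor), compound 1 gives 12700 nM and compound 2 gives 4800 nM. The change between them is trifluoromethyl in place of hydrogen on an aromatic carbon, and it produced a 2.6-fold lower number from compound 1 to compound 2 (0.42 log units; beyond the scatter). In this assay compound 3 gives 100000 nM. Compound 4 `CC(O)(COc1ccc(C#N)cc1C(F)(F)F)C(=O)Nc1ccc(S(F)(F)(F)(F)F)cc1` differs from compound 3 by trifluoromethyl in place of hydrogen on an aromatic carbon, the same kind of change, though here the place is ortho to a large group and meta to a cyano group, whereas in compound 2 it is meta to a large group and meta to a trifluoromethyl group. Compound 4 is expected to show a 2.5-fold lower number from compound 3 to compound 4 (0.40 log units; beyond the scatter) in this assay, a step of similar size to the earlier one, an expectation resting on a 2.6-fold lower number from compound 1 to compound 2 (0.42 log units; beyond the scatter). Compound 4 is accordingly estimated at 40000 nM, most likely between 12000 nM and 100000 nM.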

Compound 4, half-maximal inhibitory concentration: 100000 nM
The estimate for compound 4 lay 2.5-fold (0.40 log units) below the measured number; measured number inside the range.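

The same change gave no change at the digits printed from compound 3 to compound 4 (within the scatter) in this assay. Set beside the earlier step, the two cannot be told apart: the same change on two cores in this assay, a 2.6-fold lower number (0.42 log units; beyond the scatter) from compound 1 to compound 2 and no change at the digits printed (within the scatter) from compound 3 to compound 4, 2.6-fold (0.42 log units) apart, within the scatter of two such steps. The pair therefore does not show that the lowering carries from one core to the other, nor that it fails to, and with a single step on each core, the effect of the core cannot be separated from that of the place, which in compound 4 is ortho to a large group.

The compounds shown leave open whether a chlorine atom or a methoxy group at that same carbon would lower the number on the core of compound 3. They also leave open whether trifluoromethyl at another carbon of that ring would do so.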